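Replacing a trimethoxyphenyl with a dihydroxyphenyl

A few compounds are considered here, and "the series" means these few. Any claim that something is new, unique, unknown or untested is made for them only; others in the source may bear on it.

Measured so far in a functional assay on A549 cells (Homo sapiens) for cytotoxicity, read by MTT assay, with a stated time of 72 h; a higher number here means a weaker inhibitor, a lower number a stronger inhibitor:
compound 1 `COc1ccc(/C=N/NC(=O)Nc2ccc(Oc3ccnc(-c4nncn4CCN(C)C)c3)c(F)c2)c(OC)c1OC` gives 6680 nM
compound 2 `CN(C)CCn1cnnc1-c1cc(Oc2ccc(NC(=O)N/N=C/c3ccc(O)cc3)cc2F)ccn1` gives 3560 nM

Going by the values given here, compound 1 has the higher of the two numbers, yet its only neighbour, compound 2, lies within the scatter, as the step of a 1.9-fold lower number from compound 1 to compound 2 (0.27 log units; within the scatter) shows. Compound 3 `CN(C)CCn1cnnc1-c1cc(Oc2ccc(NC(=O)N/N=C/c3ccc(O)cc3O)cc2F)ccn1` is not yet measured. It differs from compound 1 in one place: 2,4-dihydroxyphenyl in place of 2,3,4-trimethoxyphenyl on a carbon with a double bond to nitrogen. Among the compounds with values here, the one step that bears on this, a 1.9-fold lower number from compound 1 to compound 2 (0.27 log units; within the scatter), likewise put 4-hydroxyphenyl in place of 2,3,4-trimethoxyphenyl and stayed within the scatter, so nothing beyond the scatter is expected here either. Compound 3 is therefore estimated at 4000 nM, between 1500 nM and 10000 nM. The expected step, a 1.7-fold lower number from compound 1 to compound 3 (0.22 log units; within the scatter), stays within the scatter.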

Compound 3, half-maximal inhibitory concentration: 12700 nM
Compound 3: the middle estimate sits 3.2-fold (0.50 log units) below what was measured, outside the stated range (above it).
By their numbers in this assay, from the lowest: compounds 2, 1 and 3 (each within the scatter of the next, the first and the last beyond it).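

Hydroxy in place of hydrogen on an aromatic carbon gives, in this assay, a 3.6-fold higher number from compound 2 to compound 3 (0.55 log units; beyond the scatter), a modest step and the first beyond the scatter at this position. Set against the 2,3,4-trimethoxyphenyl, the 2,4-dihydroxyphenyl gives a 1.9-fold higher number from compound 1 to compound 3 (0.28 log units; within the scatter), so a change on this ring can move the number, though only one pair of compounds shows it. No measurement at hand explains this step. Still open, from the compounds shown here alone, is whether an amino group or a carboxylic acid in place of that added hydroxy would give a similar step.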